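This account rests on a few compounds, and the source may have more. Where it says the series, first, only, none or still open, it means among the compounds named here.

Of the compounds shown here, three that share one core have been tested in a functional assay on COR-L23 cells (Homo sapiens) for antiproliferative activity, read by CellTiter-Glo, with a stated time of 72 h; on this read-out higher numbers stand for weaker inhibition and lower numbers for stronger inhibition. Compound 1 `C[C@@H](c1ccc(NC(=O)N2CC(c3cncc(N)c3)C2)cc1)N1Cc2ccccc2C1=O` gives 130 nM, compound 2 `C[C@H](NC(=O)c1cccc(F)c1)c1ccc(NC(=O)N2CC(c3cncc(N)c3)C2)cc1` gives 630 nM, and compound 3 `C[C@H](NC(=O)c1ncccn1)c1ccc(NC(=O)N2CC(c3cncc(N)c3)C2)cc1` gives 1380 nM. Compound 3 therefore has the highest number of the three, which makes it the weakest inhibitor in this small set. Compound 2 lies closest to it and compound 1 furthest away.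

The next structure, compound 4 `C[C@H](NC(=O)C1CCOCC1)c1ccc(NC(=O)N2CC(c3cncc(N)c3)C2)cc1`, alters only the group on a carbonyl carbon: oxan-4-yl in place of pyrimidin-2-yl on a carbonyl carbon. In words, oxan-4-yl stands in place of pyrimidin-2-yl, so the six-membered ring is no longer aromatic.

The closest guide is a 2.2-fold higher number from compound 2 to compound 3 (0.34 log units; beyond the scatter), a modest step made by exchanging the group on that same carbonyl carbon. The larger steps, a 4.8-fold higher number from compound 1 to compound 2 (0.69 log units; beyond the scatter) and an 11-fold higher number from compound 1 to compound 3 (1.03 log units; beyond the scatter), replace a group on a saturated chain carbon instead, so they bear on this change less directly. For the measured compounds named here, no compound with oxan-4-yl has been measured yet, which leaves the direction uncertain.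

In this assay, going by the values given here, the expected result is a small shift toward a lower number, a 1.6-fold lower number from compound 3 to compound 4 (0.21 log units; within the scatter), with no step clearly beyond the scatter. For compound 4 the estimated value is 850 nM, with an expected range from 280 nM to 2600 nM.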

Compound 4, half-maximal inhibitory concentration: 970 nM
Compound 4: middle estimate off by 1.1-fold (0.06 log units), on the low side; the range from low to high includes it.
By their numbers in this assay, from the lowest: compound 1; then compounds 2, 4 and 3 (each within the scatter of the next, the first and the last beyond it).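

On this carbonyl carbon in this assay, a ring that is not aromatic can stand in for an aromatic one without a clear loss or gain: oxan-4-yl in place of pyrimidin-2-yl gives a 1.4-fold lower number from compound 3 to compound 4 (0.15 log units; within the scatter) and oxan-4-yl in place of 3-fluorophenyl gives a 1.5-fold higher number from compound 2 to compound 4 (0.19 log units; within the scatter) (both within the scatter), although compound 2 and compound 3 themselves lie just beyond the scatter of each other. Among these three compounds, then, an aromatic ring on this carbon is not needed to keep the activity at this level. The gap to compound 1 remains, with the group on the saturated chain carbon accounting for the larger difference (a 7.5-fold higher number from compound 1 to compound 4 (0.87 log units; beyond the scatter)), and compound 1 is still the strongest inhibitor of the set. No measurement here offers a reason for any of these differences. Going by these compounds, all three groups on this carbonyl carbon are six-membered rings, so it remains open how a carbonyl carbon carrying a simple methyl group, a longer chain or an open-chain amine would behave. A carboxylic acid on the ring of oxan-4-yl is equally untested by the compounds shown here.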